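Three Limits and a Fourth Hydrazone Awaiting Measurement

A few compounds are considered here, and "the series" means these few. Any claim that something is new, unique, unknown or untested is made for them only; others in the source may bear on it.

Compound 1 `CC1CC/C(=N\Nc2ccccc2I)c2ncc(C(=O)O)c(=O)n21` — > 1000 umol/kg
Compound 2 `CCOc1ccccc1N/N=C1\CCC(C)n2c1ncc(C(=O)O)c2=O` — > 1000 umol/kg
Compound 3 `CC1CC/C(=N\Nc2ccccc2[N+](=O)[O-])c2ncc(C(=O)O)c(=O)n21` — > 1000 umol/kg

In a functional assay on the whole organism for inhibition, with Rattus norvegicus as the target (a lower number here means that less compound is needed, a higher number that more compound is needed for the effect), compound 1 gives > 1000 umol/kg, which is a limit of the assay and not a number. Compound 2 also gives > 1000 umol/kg, again a limit. Compound 3 gives > 1000 umol/kg, a limit as well. All three therefore sit at the same point: the limit of > 1000 umol/kg in this assay, at which 3 of the 3 values shown sit. The steps between them, a step that the two limits leave unreadable from compound 1 to compound 2, a step that the two limits leave unreadable from compound 1 to compound 3 and a step that the two limits leave unreadable from compound 2 to compound 3, cannot be read, since both ends of each are limits.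

Compound 4 `CCc1ccc(N/N=C2\CCC(C)n3c2ncc(C(=O)O)c3=O)cc1` is not yet measured. Against compound 1 the change is 4-ethylphenyl in place of 2-iodophenyl on an amine nitrogen. Among the compounds with values here, none of the measured steps bears directly on this change; each of them alters only the substituent on the aromatic ring while keeping it in the same place, and none yields a readable size. There is thus no basis for expecting a step in either direction beyond the scatter. The step from compound 1 is expected to be a step that the limit leaves unreadable from compound 1 to compound 4. For compound 4 the estimated value is 1500 umol/kg, with a range from 300 umol/kg to 10000 umol/kg, and most likely only a limit will be reported again.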

Compound 4, dose for 50% inhibition: > 1000 umol/kg
Compound 4: only a limit was reported; the forecaster's own chance of this, stated with the estimate: 75%; the middle value lies beyond the limit too.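

Compound 4 gives > 1000 umol/kg in this assay, again a limit of the assay and not a number. The step from compound 1 to compound 4 therefore cannot be read, since both ends are limits: the limit of > 1000 umol/kg in this assay, at which 4 of the 4 values shown sit.

The compounds shown leave open what dose, if any, gives the effect for any of these four compounds, and so whether the groups compared differ at all.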